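Swapping Dimethylamino for Methoxy on Two Related Cores

A few compounds are considered here, and "the series" means these few. Any claim that something is new, unique, unknown or untested is made for them only; others in the source may bear on it.

Compound 1 `CN(C)c1cccc(Nc2nccc(-c3cccnc3)n2)c1` and compound 2 `COc1cccc(Nc2nccc(-c3cccnc3)n2)c1` share one core and differ in a single place: methoxy in place of dimethylamino on an aromatic carbon. In a functional assay for inhibition, with Homo sapiens as the target (on this read-out higher numbers stand for weaker inhibition and lower numbers for stronger inhibition), compound 1 gives 1800 nM. In this assay compound 2 gives 300 nM, so this swap produced a 6.0-fold lower number from compound 1 to compound 2 (0.78 log units; beyond the scatter).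

Compound 3 `Cc1cc(-c2ccncc2)nc(Nc2cccc(N(C)C)c2)n1` sits on a different core; the difference between the two cores is not broken down here. In this assay compound 3 gives > 24000 nM, which is a limit of the assay and not a number. That reading corresponds to the limit of > 24000 nM in this assay, at which 1 of the 3 values shown sits.

Compound 4 `COc1cccc(Nc2nc(C)cc(-c3ccncc3)n2)c1` has not yet been measured. It differs from compound 3 by the same change seen between compound 1 and compound 2: methoxy in place of dimethylamino on an aromatic carbon. The place of the change is the same in both pairs.

The step is expected to repeat in direction because the earlier swap gave a 6.0-fold lower number from compound 1 to compound 2 (0.78 log units; beyond the scatter), and a step of about an at least 3.0-fold lower number from compound 3 to compound 4 (0.47 log units; beyond the scatter) is estimated. Since the starting value of compound 3 is only a limit, the estimate for compound 4 remains wide, with an expected value of 8000 nM and a likely range from 2000 nM to 40000 nM.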

Compound 4, half-maximal inhibitory concentration: > 24000 nM
Compound 4: only a limit was reported; the forecaster's own chance of this, stated with the estimate: 35%; middle value at least 3.0-fold (0.47 log units) away from the limit.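

In this assay compound 4 gives > 24000 nM, which is a limit of the assay and not a number. Compound 3 sits at the same limit, so no step can be read between compound 3 and compound 4: the limit of > 24000 nM in this assay, at which 2 of the 4 values shown sit. The compounds shown leave open whether methoxy in place of dimethylamino changes the number at all on this core.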